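Removing a distant ring ether from a chain-bearing ketoamide

The compounds below may be only part of what the source reports. "The series", "measured", "known", "first", "only" and "open" are said of these compounds alone.

Two compounds have numbers in a functional assay on microsomes from intestine for inhibition of acyl-CoA:cholesterol acyltransferase (Oryctolagus cuniculus); on this read-out lower numbers stand for stronger inhibition and higher numbers for weaker inhibition. Compound 1, `CCCCCCCCCCCC(=O)C(C)(C)C(=O)Nc1c(OC)cc(OC)cc1OC`, gives 370 nM. Compound 2, `CC(C)c1cccc(C(C)C)c1NC(=O)CC(=O)CCCCCCCCCCOC1CCCCO1`, gives 57 nM, the lowest of the two numbers; compound 1 is the nearer of the two and stands beyond the scatter from it. The two differ in several places at once, so only their two values can be compared.

Compound 3, `CCCCCCCCCCCCC(=O)CC(=O)Nc1c(C(C)C)cccc1C(C)C`, has not been measured. It follows from compound 2 by one change: ethyl in place of (oxan-2-yl)oxy on a saturated chain carbon, ten or more bonds along the chain from a carbonyl carbon. The chain keeps its length in heavy atoms at the far end, and the amide, the ketone and the core of compound 2 are untouched.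

Going by the values given here, no measured pair shows this change. The change sits far from the carbonyls, and the step from compound 2 to compound 3 is expected to be small, most likely within the scatter, with the balance tipped toward a slightly lower number. The estimated step is a 1.4-fold lower number from compound 2 to compound 3 (0.15 log units; within the scatter). For compound 3 the expected value in this assay is 40 nM, with a range from 12 nM to 130 nM.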

Compound 3, half-maximal inhibitory concentration: 11 nM
For compound 3 the middle estimate is 3.6-fold (0.56 log units) above the measured one; the whole stated range lies above it.
By their numbers in this assay, from the lowest: compound 3; then compound 2; then compound 1.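

In this assay, the saturated chain carbon that carries the change proves responsive: ethyl in place of (oxan-2-yl)oxy gives a 5.2-fold lower number from compound 2 to compound 3 (0.71 log units; beyond the scatter) and this step lies beyond the scatter. The earlier compounds shown here could not show this, as they differ in several places at once, whereas this pair isolates a single change with the amide, the ketone and the core left untouched. Within this one pair, the plain hydrocarbon chain, with no ring and no hydrogen-bond acceptors at this place, goes with the stronger inhibition, and no measurement offered here accounts for the step.

As far as these compounds go, the pair cannot separate the loss of the ring from the loss of the ether oxygen, so it remains open how a methoxy group, a hydroxyl group, a carboxylic acid or a longer chain would read at this place. From the compounds shown here alone, it also remains open whether the same change would carry the same step on the core of compound 1, whose trimethoxy-substituted aryl amide and gem-dimethyl carbon set it apart from this pair.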